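The source may hold more compounds than are shown below. What is called first, only, known or untested is meant among the compounds shown, and "the series" means these compounds.

The three measured compounds are compared in a functional assay on HCT-116 cells (Homo sapiens) for inhibition, read by CCK-8 assay, with a stated time of 72 h, tested at 2 uM; a higher number here means more inhibition of growth at the concentration tested, a lower number less inhibition of growth. Compound 2 `Cc1ccc(SCc2ccc(C(=O)Nc3ccccc3N)cc2)cc1` gives 74.8%. Compound 1 `Cc1cc(C)cc(SCc2ccc(/C=C/C(=O)Nc3ccccc3N)cc2)c1` gives 7.98%. Compound 3 `CC(C)(C)c1ccc(SCc2ccc(C(=O)Nc3ccccc3N)cc2)cc1` gives 4.81%, the lowest of the three numbers; it lies within the scatter of compound 1 and far beneath compound 2. For the measured compounds named here, the only measured step that reaches compound 3 is a number 70 percentage points lower from compound 2 to compound 3 (beyond the scatter), a large fall that shows how strongly a single change on that aromatic carbon can move the read-out.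

Compound 4 `Nc1ccccc1NC(=O)c1ccc(CSc2ccc(F)cc2)cc1` differs from compound 3 by fluoro in place of tert-butyl on an aromatic carbon. The incoming fluoro sits on an aromatic carbon of a six-membered aromatic ring of carbon only, para to a large group. Going by the values given here, no measured compound carries a fluoro, so the expectation rests on the single step above: removing the tert-butyl is expected to undo at least part of that fall. Compound 4 is therefore expected to show a number 40.2 percentage points higher from compound 3 to compound 4 (beyond the scatter), because compound 3 gives 4.81% while compound 2, with a small group at the same place, gives 74.8%. The estimate for compound 4 is 45%, with a range from 10% to 80%.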

Compound 4, percent growth inhibition at one concentration: 13.5%
For compound 4 the middle estimate is 31.5 percentage points above the measured one; the range from low to high includes it.
By their numbers in this assay, from the lowest: compounds 3, 1 and 4 (each within the scatter of the next); then compound 2.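

In this assay the exchange of tert-butyl for fluoro gives a number 8.7 percentage points higher from compound 3 to compound 4 (within the scatter), so going from 4 heavy atoms to 1 heavy atom on this aromatic carbon does not by itself restore the high read-out. Set against methyl, the same fluoro gives a number 61.3 percentage points lower from compound 2 to compound 4 (beyond the scatter), which leaves compound 2 alone at the high end among the three compounds that differ only at this place, so the earlier fall cannot be read simply as the price of a large group. Nothing available gives a reason for this difference between methyl and fluoro.

On these data alone, whether a plain hydrogen, chloro, methoxy or an amine at this place would side with compound 2 or with compound 3 and compound 4 stays open. So does whether methyl alone carries the high read-out, or whether an ethyl group would keep it too.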